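From Methoxy to Nitro on the Aromatic Ring

This account rests on a few compounds, and the source may have more. Where it says the series, first, only, none or still open, it means among the compounds named here.

In a toxicity assay on WI-38 cells (Homo sapiens) for inhibition, read by MTT assay, with a stated time of 48 h (a higher number here means a weaker inhibitor, a lower number a stronger inhibitor), compound 1 `Cc1ccc(/C=C2\SC(=O)N(CC(=O)Nc3c(C)n(C)n(-c4ccccc4)c3=O)C2=O)cc1` gives 83700 nM and compound 2 `COc1ccc(/C=C2\SC(=O)N(CC(=O)Nc3c(C)n(C)n(-c4ccccc4)c3=O)C2=O)cc1` gives 52900 nM. Among the measured compounds shown here, compound 2 therefore stands level with compound 1, the only other measured compound, since a 1.6-fold lower number from compound 1 to compound 2 (0.20 log units; within the scatter).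

Compound 3 `Cc1c(NC(=O)CN2C(=O)S/C(=C\c3ccc([N+](=O)[O-])cc3)C2=O)c(=O)n(-c2ccccc2)n1C` keeps the shared core of compound 2 but carries nitro in place of methoxy on an aromatic carbon, para to a large group (nitro in place of methoxy on an aromatic carbon). For the measured compounds named here, the only measured step that bears on this change is a 1.6-fold lower number from compound 1 to compound 2 (0.20 log units; within the scatter), which was methoxy in place of methyl on an aromatic carbon. Going by the values given here, no nitro compound has yet been measured, so this single small step is a thin guide, and no shift beyond the scatter is expected. The estimate amounts to an expected 1.1-fold higher number from compound 2 to compound 3 (0.05 log units; within the scatter). For compound 3 the expected value is 60000 nM, within an estimated range of 25000 nM to 140000 nM.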

Compound 3, half-maximal inhibitory concentration: 43800 nM
Compound 3: middle estimate off by 1.4-fold (0.14 log units), on the high side; the range from low to high includes it.
By their numbers in this assay, from the lowest: compounds 3, 2 and 1 (each within the scatter of the next).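

On the aromatic carbon para to a large group, nitro in place of methoxy gives a 1.2-fold lower number from compound 2 to compound 3 (0.08 log units; within the scatter), and nitro in place of methyl gives a 1.9-fold lower number from compound 1 to compound 3 (0.28 log units; within the scatter). In this assay, methyl, methoxy and nitro at this position therefore all stand within the scatter of one another, which the first two compounds, with only methyl and methoxy to compare, could not show. Nothing available gives a reason for this result.

On these data alone, whether an amine, a carboxylic acid or a fluorine atom at this same position would also stay within the scatter of these three remains open. All three compounds keep the rest of the structure unchanged, so what a longer chain in place of the methyl on the shared core would do to the number is open as well.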